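The source may hold more compounds than are shown below. What is called first, only, known or untested is meant among the compounds shown, and "the series" means these compounds.

Compound 1 `Cc1ccc(-c2n[nH]c3c2CCNCC3)cc1` carries a methyl group on its outer benzene ring, and in an assay on cells for displacement of a labelled ligand from 5-hydroxytryptamine receptor 1D (Homo sapiens), read by scintillation counting, with a stated time of 1.5 h (a higher number here means a weaker inhibitor, a lower number a stronger inhibitor), compound 1 gives 165 nM. Compound 2 `Fc1ccc(-c2n[nH]c3c2CCNCC3)cc1` has a fluoro group in that place instead; in this assay compound 2 gives 636 nM, the highest of the two numbers reported, reached through the step of a 3.9-fold higher number from compound 1 to compound 2 (0.59 log units; beyond the scatter). Compound 3 `Clc1ccc(-c2noc3c2CCNCC3)cc1`, built on a different core, shows in this assay only > 10000 nM, which is a limit of the assay and not a number (the limit of > 10000 nM in this assay, at which 1 of the 3 values shown sits). Compound 4 `Clc1ccc(-c2n[nH]c3c2CCNCC3)cc1` differs from compound 2 by chloro in place of fluoro on an aromatic carbon. Going by the values given here, the single step that touches this place, from methyl to fluoro, was modest, so a modest move back downward is expected for compound 4, estimated as a 2.3-fold lower number from compound 2 to compound 4 (0.36 log units; beyond the scatter). Compound 4 is therefore estimated at 280 nM, with a likely range from 90 nM to 900 nM.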

Compound 4, inhibition constant: 2110 nM
For compound 4 the middle estimate is 7.5-fold (0.88 log units) below the measured one, outside the stated range (above it).
By their numbers in this assay, from the lowest: compound 1; then compound 2; then compound 4. At a limit, above all of these: compound 3.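

Chloro in place of fluoro gives a 3.3-fold higher number from compound 2 to compound 4 (0.52 log units; beyond the scatter) in this assay, so this place on the ring still responds when one halogen replaces another, and the number moves further up rather than back toward that of the methyl compound. Chloro in place of methyl gives a 13-fold higher number from compound 1 to compound 4 (1.11 log units; beyond the scatter) and is the largest step seen here, so both halogens leave weaker inhibitors than methyl does. Nothing measured here explains this order. On these data alone, whether an amine, a methoxy group or a nitrile in this place would bring the number below that of compound 1 stays open.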